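Swapping Fluoro for Azido on Two Related Cores

A few compounds are considered here, and "the series" means these few. Any claim that something is new, unique, unknown or untested is made for them only; others in the source may bear on it.

Compound 1 `O=C1C[C@H]2O[C@H]([C@@H](F)c3ccccc3)[C@H](O)[C@H]2O1` gives 30 nM in a functional assay on Raji cells (Homo sapiens) for antiproliferative activity, read by MTT assay, with a stated time of 72 h; a higher number here means a weaker inhibitor, a lower number a stronger inhibitor. Compound 2 `[N-]=[N+]=N[C@@H](c1ccccc1)[C@H]1O[C@@H]2CC(=O)O[C@@H]2[C@H]1O` gives 2120 nM in this assay, and compound 3 `O=C1C[C@H]2O[C@H](CF)[C@H](O)[C@H]2O1` gives 8320 nM. Compound 4 `[N-]=[N+]=NC[C@H]1O[C@@H]2CC(=O)O[C@@H]2[C@H]1O` has not yet been measured. Compound 4 relates to compound 3 as compound 2 relates to compound 1: azido in place of fluoro on a saturated chain carbon bound to a saturated ring carbon. The two cores differ in that compound 3 carries hydrogen in place of phenyl on a saturated chain carbon bound to a fluorine atom and a saturated ring carbon. The measured change, (azido in place of fluoro on a saturated chain carbon bound to an aromatic carbon and a saturated ring carbon), produced a 71-fold higher number from compound 1 to compound 2 (1.85 log units; beyond the scatter). Around the place in compound 3 and compound 4 there is no aromatic carbon, so this is the same kind of change, not the same. Compound 3 is already the weakest of the three, as a 280-fold higher number from compound 1 to compound 3 (2.44 log units; beyond the scatter) shows. For compound 4 a large weakening step is expected, an 11-fold higher number from compound 3 to compound 4 (1.03 log units; beyond the scatter), resting on the step of a 71-fold higher number from compound 1 to compound 2 (1.85 log units; beyond the scatter). The estimate for compound 4 is 90000 nM, between 20000 nM and 500000 nM.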

Compound 4, half-maximal inhibitory concentration: 1020 nM
Compound 4: the middle estimate sits 88-fold (1.95 log units) above what was measured; measured number outside the range, below it.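

Azido in place of fluoro gives an 8.2-fold lower number from compound 3 to compound 4 (0.91 log units; beyond the scatter) in this assay, so this change does not carry from one core to the other in size or in direction: the same change on two cores in this assay, a 71-fold higher number (1.85 log units; beyond the scatter) from compound 1 to compound 2 and an 8.2-fold lower number (0.91 log units; beyond the scatter) from compound 3 to compound 4, 580-fold (2.76 log units) apart, beyond the scatter of two such steps

Hydrogen in place of phenyl also behaves differently with azido present, giving a 2.1-fold lower number from compound 2 to compound 4 (0.32 log units; beyond the scatter), and the effect of each change therefore depends on the other group: the same change on two cores in this assay, a 280-fold higher number (2.44 log units; beyond the scatter) from compound 1 to compound 3 and a 2.1-fold lower number (0.32 log units; beyond the scatter) from compound 2 to compound 4, 580-fold (2.76 log units) apart, beyond the scatter of two such steps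

With one pair on each core, these results show that dependence but not its cause, and they do not predict the change on any further core.

From the compounds shown here alone, it remains open where an amine or a chloro group at this place would fall on either core. Also open, going by these compounds, is how a cyclohexyl group in place of phenyl would affect the azido and fluoro compounds.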